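From Amide to Acid on a Shared Core

The source may report more compounds than this note shows. Statements on the series, on what has been measured and on what is new or still open speak of the compounds shown alone.

Measured compounds:
Compound 1, `Nc1c([S+]([O-])CCCF)sc2nc(-c3cccs3)cc(-c3ccccc3)c12`, gives 6.1 nM in an assay for inhibition of 15-hydroxyprostaglandin dehydrogenase [NAD(+)] (Homo sapiens), read by fluorescence, with a stated time of 15 min, in the presence of a further agent that is not named here; a higher number here means a weaker inhibitor, a lower number a stronger inhibitor.
Compound 2, `CCCNC(=O)c1sc2nc(-c3cccs3)cc(-c3ccccc3)c2c1N`, gives > 7500 nM in this assay; this is a limit of the assay, not a number.

Compound 2 therefore stands at the weak end of what the assay can report, as shown by the limit of > 7500 nM in this assay, at which 1 of the 2 values shown sits. Among the compounds with values here, the only measured step is an at least 1200-fold higher number from compound 1 to compound 2 (3.08 log units; beyond the scatter), which places compound 2 far from compound 1. Compound 3, `Nc1c(C(=O)O)sc2nc(-c3cccs3)cc(-c3ccccc3)c12`, differs from compound 2 by hydroxy in place of propylamino on a carbonyl carbon. Within the data shown here, no measured step covers this kind of change, so there is nothing to anchor a direction; the starting point is itself a limit. Compound 3 is expected to remain near or beyond that limit, with an estimated value of 20000 nM, ranging from 5000 nM to 80000 nM. The expected step is a step that the limit leaves unreadable from compound 2 to compound 3, which cannot be resolved beyond the scatter from a limit.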

Compound 3, half-maximal inhibitory concentration: > 7500 nM
Compound 3: only a limit was reported; the forecaster's own chance of this, stated with the estimate: 75%; the middle value does not contradict the limit.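

In this assay compound 3 gives > 7500 nM, which is a limit of the assay and not a number. Putting carboxy on the aromatic carbon, a smaller group than propylcarbamoyl, still gives a large change on the shared core: an at least 1200-fold higher number from compound 1 to compound 3 (3.08 log units; beyond the scatter). So a second, quite different group in this place fails to keep the strength of compound 1, while the step between compound 2 and compound 3 cannot be read, and the weak end of the assay now holds most of the set: the limit of > 7500 nM in this assay, at which 2 of the 3 values shown sit.

On these data alone, how weak compound 2 and compound 3 really are stays open, so the two cannot be put in order. Also open, as far as these compounds go, is whether a methyl ester or a primary amide in this place would bring the number back towards that of compound 1.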